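The compounds below may be only part of what the source reports. "The series", "measured", "known", "first", "only" and "open" are said of these compounds alone.

Measured so far:
compound 1 `CCCCOC(=O)NS(=O)(=O)c1sc(CC(C)C)cc1-c1ccc(C(=O)c2ncco2)cc1` — 13.8 nM
compound 2 `CCCCOC(=O)NS(=O)(=O)c1sc(CC(C)C)cc1-c1ccc(Cn2cnc(C(F)(F)F)c2)cc1` — 7.3 nM

In an assay on membranes from uterus for displacement of a labelled ligand from Angiotensin type II receptor (Sus scrofa), with a stated time of 1.5 h (on this read-out lower numbers stand for stronger inhibition and higher numbers for weaker inhibition), compound 2 gives 7.3 nM and compound 1 gives 13.8 nM; the two lie within the scatter of each other, as shown by a 1.9-fold lower number from compound 1 to compound 2 (0.28 log units; within the scatter). Compound 3 `CCCCOC(=O)NS(=O)(=O)c1sc(CC(C)C)cc1-c1ccc(Cn2ccc(C(F)(F)F)n2)cc1` differs from compound 2 by 3-(trifluoromethyl)-1H-pyrazol-1-yl in place of 4-(trifluoromethyl)-1H-imidazol-1-yl on a saturated chain carbon bound to an aromatic carbon. Within the data shown here, no measured step covers this exact exchange; the only step available, a 1.9-fold lower number from compound 1 to compound 2 (0.28 log units; within the scatter), swapped one five-membered aromatic ring for another and stayed within the scatter. Compound 3 is therefore expected to remain close to compound 2, a 1.1-fold higher number from compound 2 to compound 3 (0.04 log units; within the scatter). In this assay the value of compound 3 is estimated at 8 nM, with a range from 3.5 nM to 18 nM.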

Compound 3, inhibition constant: 9.5 nM
Beside the measured number, compound 3's estimate is 1.2-fold (0.07 log units) below it, and the stated range covers the measured number.
By their numbers in this assay, from the lowest: compounds 2, 3 and 1 (each within the scatter of the next).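

In this assay, 3-(trifluoromethyl)-1H-pyrazol-1-yl in place of 4-(trifluoromethyl)-1H-imidazol-1-yl, the same atoms joined differently, gives a 1.3-fold higher number from compound 2 to compound 3 (0.11 log units; within the scatter) and so shows that this rearrangement of the ring on the saturated chain carbon stays within the scatter. The wider exchange, (3-(trifluoromethyl)-1H-pyrazol-1-yl)methyl in place of (1,3-oxazol-2-yl)carbonyl, gives a 1.5-fold lower number from compound 1 to compound 3 (0.16 log units; within the scatter) and also stays within it. No evidence is available on what lies behind these results.

The compounds shown leave open whether a carboxylic acid or an amine in place of the ring would stay in this range. They also leave open whether a nitrile could replace the trifluoromethyl on the pyrazole.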